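Amide change from compound 2 to compound 3

This account rests on a few compounds, and the source may have more. Where it says the series, first, only, none or still open, it means among the compounds named here.

Within the data shown here, in a functional assay on HUVEC cells (Homo sapiens) for inhibition, with a stated time of 4 days (on this read-out higher numbers stand for weaker inhibition and lower numbers for stronger inhibition), two compounds have numbers so far: compound 1 (`COC(=O)c1ccc(OC)c(COc2ccc(Cl)c(C)c2)c1`) with 2300 nM and compound 2 (`CNC(=O)c1ccc(OC)c(/C=C/c2ccc(Cl)cc2)c1`) with 190 nM as the lower of the two, a gap beyond the scatter. These two differ in more than one place, so their gap cannot be assigned to any single change.

Compound 3 (`COc1ccc(C(=O)NC(CO)CO)cc1/C=C/c1ccc(Cl)cc1`) keeps the rest of compound 2 and alters only the amide: 2-hydroxy-1-(hydroxymethyl)ethyl in place of methyl on an amide-type nitrogen. In words, this is 2-hydroxy-1-(hydroxymethyl)ethyl in place of methyl on an amide-type nitrogen.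

Among the measured compounds shown here, no measured pair isolates a change at this nitrogen, so the data give no direct guide to the size of the step. For the measured compounds named here, the starting point is compound 2 (190 nM), the only measured compound that shares the core of compound 3. A modest move to a higher number in this assay is expected, near the edge of the scatter, and the estimate means a 2.1-fold higher number from compound 2 to compound 3 (0.32 log units; beyond the scatter) as the expected step. Compound 3 is estimated at 400 nM (expected range 120 nM to 1300 nM).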

Compound 3, half-maximal inhibitory concentration in the HUVEC assay: 1500 nM
The estimate for compound 3 lay 3.8-fold (0.57 log units) below the measured number, outside the stated range (above it).
By their numbers in the HUVEC assay, from the lowest: compound 2; then compounds 3 and 1 (each within the scatter of the next).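

In the HUVEC assay, the substituent on the amide-type nitrogen proves to matter: 2-hydroxy-1-(hydroxymethyl)ethyl in place of methyl gives a 7.9-fold higher number from compound 2 to compound 3 (0.90 log units; beyond the scatter), a loss of inhibition beyond the scatter. Among these compounds, this is the only step that isolates a single place, so this nitrogen is the one position where a substituent change can be tied directly to a shift in inhibition. In a physicochemical assay for solubility, read by HPLC, in simulated intestinal fluid, with a stated time of 2 h, tested at 10 mM (on this read-out lower numbers stand for lower solubility and higher numbers for higher solubility), compound 2 gives 24 ug/mL and compound 3 gives 251 ug/mL. The same change also has a gain attached in the physicochemical assay, so the exchange at this position is weaker inhibition for higher solubility in simulated intestinal fluid: the measured solubility of compound 2, 24 ug/mL, and of compound 3, 251 ug/mL, a 10-fold higher number (1.02 log units; beyond the scatter)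

Going by these compounds, a single step cannot separate the effect of the added carbon atoms from that of the hydroxyl groups, so the source of the loss in the HUVEC assay remains unknown, as does the source of the gain in the physicochemical assay. An isopropyl group on this nitrogen would test the branched carbon skeleton without the hydroxyl groups, while a 2-hydroxyethyl chain would show whether a smaller hydroxyl-bearing group can retain more of the inhibition of compound 2 and still raise solubility.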